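Restoring a hydrogen on the amine nitrogen of compound 3

The source may report more compounds than this note shows. Statements on the series, on what has been measured and on what is new or still open speak of the compounds shown alone.

compound 1 `CC(C)(C)NCc1cc(Cl)cc(Nc2nc3ccccc3n2Cc2ccc(C(F)(F)F)cc2)c1O`: 36%
compound 2 `CCNCc1cc(C)cc(Nc2nc3ccccc3n2Cc2ccc(C(F)(F)F)cc2)c1O`: 52%
compound 3 `CCN(CC)Cc1cc(C)cc(Nc2nc3ccccc3n2Cc2ccc(C(F)(F)F)cc2)c1O`: < 7%

All three readings come from an ADME assay on microsomes from liver (Mus musculus) for metabolic stability, read by LC-MS, with a stated time of 30 min, tested at 1 uM; a higher number here means that more of the compound is left, a lower number that less of the compound is left. Compound 3 stands at < 7%, and this is a limit of the assay, not a number.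

Compound 4 `Cc1cc(CNC(C)(C)C)c(O)c(Nc2nc3ccccc3n2Cc2ccc(C(F)(F)F)cc2)c1` has the same atoms as compound 3, joined differently: (tert-butyl)amino in place of diethylamino on a saturated chain carbon bound to an aromatic carbon. The (tert-butyl)amino group thus takes the place of diethylamino on a saturated chain carbon bound to an aromatic carbon, and the amine nitrogen carries a hydrogen again.

The measured step closest to this change is a number at least 45 percentage points lower from compound 2 to compound 3 (beyond the scatter). That large step ran towards the limit, and the change to compound 4 removes the diethylamino group that came with it. Compound 2, the partner in that step, gives 52% with its hydrogen on the nitrogen. Compound 4 carries the same (tert-butyl)amino group as compound 1 and differs from it elsewhere on the core, and compound 1 gives 36%. On these two values, a large rise in this assay is expected, and the estimated step is a number at least 33 percentage points higher from compound 3 to compound 4 (beyond the scatter). The estimate for compound 4 is 40%, with an expected range of 20% to 62%.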

Compound 4, percent of the compound remaining: 62%
Beside the measured number, compound 4's estimate is 22 percentage points below it, within the range that was stated.
By their numbers in this assay, from the lowest: compound 1; then compounds 2 and 4 (each within the scatter of the next). At a limit, below all of these: compound 3.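

In this assay, (tert-butyl)amino in place of diethylamino on a saturated chain carbon bound to an aromatic carbon, with the same atoms joined differently and a hydrogen back on the amine nitrogen, gives a number at least 55 percentage points higher from compound 3 to compound 4 (beyond the scatter). Compound 3 stands at a limit of the assay and not at a number, which leaves the size of that step open at its upper end: the limit of < 7% in this assay, at which 1 of the 4 values shown sits. Among the compounds that keep the hydrogen on this nitrogen, tert-butyl in place of ethyl gives a number 10 percentage points higher from compound 2 to compound 4 (within the scatter), while with the (tert-butyl)amino group held constant, methyl in place of chloro on an aromatic carbon gives a number 26 percentage points higher from compound 1 to compound 4 (beyond the scatter), the first sign that this second place also matters in this assay.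

Compound 3 alone lacks the hydrogen on the amine nitrogen, so the compounds shown cannot tell whether another fully substituted amine, such as dimethylamino, would sit as low as diethylamino does. They also leave open how a fluoro or a methoxy group would compare with methyl and chloro on that aromatic carbon.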